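Methoxy added beside a phenol: expected effect on glucosidase inhibition

The source may hold more compounds than are shown below. What is called first, only, known or untested is meant among the compounds shown, and "the series" means these compounds.

Measured compounds and their values in an assay on isolated protein for inhibition of lysosomal alpha-glucosidase (Rattus norvegicus), read by spectrophotometry, with a stated time of 5 min, tested at 25 ug/mL; on this read-out higher numbers stand for more inhibition at the one concentration tested (going by the name of the read-out) and lower numbers for less inhibition:
compound 1, `O=C(/C=C/c1ccccc1)c1cc2ccoc2cc1O`, 67.6%;
compound 2, `COc1ccc(/C=C/C(=O)c2cc3ccoc3cc2O)cc1`, 48.9%;
compound 3, `O=C(/C=C/c1ccc(O)cc1)c1cc2ccoc2cc1O`, 8.77%.

Compound 3 stands lowest of the three. Its nearest neighbour is compound 2, and the step of a number 40.1 percentage points lower from compound 2 to compound 3 (beyond the scatter) puts it well below that one; the step of a number 58.8 percentage points lower from compound 1 to compound 3 (beyond the scatter) puts it further still below compound 1. Both distances lie beyond the scatter, so compound 3 has the lowest number in this assay of the set.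

Compound 4, `COc1cc(/C=C/C(=O)c2cc3ccoc3cc2O)ccc1O`, keeps everything in compound 3 and adds one group: methoxy in place of hydrogen on an aromatic carbon. Among the measured compounds shown here, only one measured step involves the same kind of change: in a number 18.7 percentage points lower from compound 1 to compound 2 (beyond the scatter) a methoxy replaced a hydrogen on an aromatic carbon and the number fell modestly. That earlier methoxy sat at a different place on the ring, so the comparison is loose. Compound 3 is already close to the bottom of the percentage scale, which leaves little room for a further drop to show.

The expectation for compound 4 is therefore a number in this assay near that of compound 3 or slightly lower, a step of a number 2.8 percentage points lower from compound 3 to compound 4 (within the scatter), which would not be beyond the scatter. The estimate for compound 4 is 6%, with a range from 0% to 20%.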

Compound 4, a percentage reported as inhibition, at one concentration (the size of the read-out at that concentration, not a potency): 52.8%
The estimate for compound 4 lay 46.8 percentage points below the measured number; measured number outside the range, above it.
By their numbers in this assay, from the lowest: compound 3; then compounds 2 and 4 (each within the scatter of the next); then compound 1.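

In this assay, putting a methoxy ortho to a hydroxy group gives a number 44 percentage points higher from compound 3 to compound 4 (beyond the scatter), so the low number of compound 3 is not fixed for every compound that carries this hydroxy group. Methoxy in place of hydrogen on an aromatic carbon has no single direction in this set, and its outcome depends on the compound that receives it: the same change on two cores in this assay, a number 18.7 percentage points lower (beyond the scatter) from compound 1 to compound 2 and a number 44 percentage points higher (beyond the scatter) from compound 3 to compound 4, 62.7 percentage points apart, beyond the scatter of two such steps. The two methoxy groups also sit at different places on the ring, so these compounds cannot separate the influence of the place from that of the hydroxy group.

From the compounds shown here alone, it remains open whether an ethoxy group, a chlorine atom or an amine at this same place, ortho to the hydroxy group, would raise the number as methoxy does, which would show how much depends on methoxy itself. Going by these compounds, each number is also a reading at one concentration rather than a potency, so how far these compounds differ in potency remains unknown.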